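The source may hold more compounds than are shown below. What is called first, only, known or untested is meant among the compounds shown, and "the series" means these compounds.

Compound 1 (`O=[N+]([O-])c1cn2c(n1)[S+]([O-])CC(OCc1ccc(OCc3ccccc3)cc1)C2`) and compound 2 (`CC1(COCc2ccc(OCc3ccccc3)cc2)Cn2cc([N+](=O)[O-])nc2[S+]1[O-]`) have both been tested in an ADME assay on L929 cells (Mus musculus) for cytotoxicity; a lower number here means a stronger inhibitor, a higher number a weaker inhibitor. There compound 1 gives > 10 ug/mL as a limit, not a number. Compound 2 likewise gives > 10 ug/mL as a limit. Compound 3 (`O=[N+]([O-])c1cn2c(n1)[S+]([O-])CC(OCc1ccc(OC(F)(F)F)cc1)C2`) has trifluoromethyl in place of benzyl on an oxygen on an aromatic ring of compound 1 (trifluoromethyl in place of benzyl on an oxygen on an aromatic ring). Going by the values given here, no measured pair shows this change, so in this assay no clear direction is expected, only a step within the usual scatter (a step that the limit leaves unreadable from compound 1 to compound 3). Compound 3 is estimated at 12 ug/mL with an expected range of 6 ug/mL to 30 ug/mL in this test.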

Compound 3, half-maximal inhibitory concentration in the L929 assay: > 10 ug/mL
Compound 3: a limit, no number (the forecaster's own chance of this, stated with the estimate: 70%); the middle value is on the limit's open side.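

In the L929 assay compound 1 gives > 10 ug/mL, which is a limit and not a number. In the L929 assay compound 3 gives > 10 ug/mL, which is also a limit and not a number. Going by these compounds alone, no step between them can be read. The compounds shown leave open whether trifluoromethyl in place of benzyl changes this read-out at all. In a physicochemical assay for solubility, read by HPLC, measured as kinetic solubility (a higher number here means a more soluble compound, a lower number a less soluble compound), compound 1 gives 5.4 ug/mL and compound 3 gives 39 ug/mL. In the physicochemical assay this change gives a 7.2-fold higher number from compound 1 to compound 3 (0.86 log units; beyond the scatter).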